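The source may hold more compounds than are shown below. What is called first, only, known or untested is meant among the compounds shown, and "the series" means these compounds.

Measured compounds:
- compound 1, `C=CC1=C(C(=O)NCc2ccc(Cl)cc2)C(c2ccc(OC)c(OC)c2)OC1`: in a functional assay on A549 cells (Homo sapiens) for cytotoxicity, read by MTT assay, with a stated time of 24 h (a lower number here means a stronger inhibitor, a higher number a weaker inhibitor), compound 1 gives a limit, > 100000 nM.
- compound 2, `C=CC1=C(C(=O)Nc2ccccc2OC)C(c2ccc(F)cc2)OC1`: in this assay compound 2 gives a limit, > 100000 nM.
- compound 3, `C=CC1=C(C(=O)Nc2ccccc2OC)C(c2ccc(OC)cc2)OC1`: in this assay compound 3 gives a limit, > 100000 nM.

Among the measured compounds shown here, compound 2 stands at the limit of this assay, and every value shown sits at that same limit (the limit of > 100000 nM in this assay, at which 3 of the 3 values shown sit), so no compound can be placed above or below another on the numbers given. For the measured compounds named here, the only step between two measured compounds, a step that the two limits leave unreadable from compound 2 to compound 3, is the change of methoxy in place of fluoro on an aromatic carbon; its size cannot be read, as both ends are limits.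

Compound 4, `C=CC1=C(C(=O)Nc2cccc(C)c2)C(c2ccc(F)cc2)OC1`, differs from compound 2 as follows: 3-methylphenyl in place of 2-methoxyphenyl on an amide-type nitrogen. Going by the values given here, no measured step touches the group on the amide-type nitrogen, so nothing here indicates a direction for this change. The expectation is therefore that compound 4 behaves like compound 2 in this assay and most likely returns a limit as well, the expected step being a number no higher from compound 2 to compound 4 (the limit leaves the size open). The estimate for compound 4 in this assay is 100000 nM, with a range from 30000 nM to 300000 nM.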

Compound 4, half-maximal inhibitory concentration: > 100000 nM
Compound 4 ended at the assay's limit (the forecaster's own chance of this, stated with the estimate: 85%); the middle value lies on the limit itself.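

Compound 4 gives > 100000 nM in this assay, which is a limit, so the change from compound 2 to compound 4 cannot be read, with both ends at limits: the limit of > 100000 nM in this assay, at which 4 of the 4 values shown sit.

The compounds shown leave open whether 3-methylphenyl or 2-methoxyphenyl on an amide-type nitrogen makes any difference in this assay, as no measured value has yet been obtained inside the range of the assay.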